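This account rests on a few compounds, and the source may have more. Where it says the series, first, only, none or still open, it means among the compounds named here.

Compound 1, with the structure `CN(C)CN1C(=O)C(=O)c2c(Br)cccc21`, gives 49000 nM in a functional assay on MDA-MB-468 cells (Homo sapiens) for cytotoxicity, read by sulforhodamine B assay, with a stated time of 48 h; on this read-out lower numbers stand for stronger inhibition of growth and higher numbers for weaker inhibition of growth. Compound 2, with the structure `O=C1C(=O)N(CN2CCCCC2)c2cccc(Br)c21`, gives 35300 nM in this assay. The two differ only by piperidin-1-yl in place of dimethylamino on a saturated chain carbon bound to an amide-type nitrogen in a ring, and that change made a 1.4-fold lower number from compound 1 to compound 2 (0.14 log units; within the scatter).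

Compound 3, with the structure `Cc1ccc2nc(/N=C3\C(=O)N(CN(C)C)c4cccc(Cl)c43)sc2c1`, carries a different core; the difference between its core and the core of compound 1 is not broken down here. In this assay compound 3 gives 28100 nM, a number that stands close to those of compound 1 and compound 2.

Compound 4, with the structure `Cc1ccc2nc(/N=C3\C(=O)N(CN4CCCCC4)c4cccc(Cl)c43)sc2c1`, has not yet been measured. It differs from compound 3 by piperidin-1-yl in place of dimethylamino on a saturated chain carbon bound to an amide-type nitrogen in a ring, the same change as that from compound 1 to compound 2. The step from compound 3 to compound 4 is therefore expected to be a 1.3-fold lower number from compound 3 to compound 4 (0.13 log units; within the scatter), resting on the earlier step of a 1.4-fold lower number from compound 1 to compound 2 (0.14 log units; within the scatter), which stayed within the scatter. On that basis compound 4 is estimated to give 21000 nM, with a likely range from 8000 nM to 50000 nM.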

Compound 4, concentration for 50% growth inhibition: 19800 nM
Compound 4: the middle estimate sits 1.1-fold (0.03 log units) above what was measured, within the range that was stated.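

In this assay, piperidin-1-yl in place of dimethylamino on a saturated chain carbon bound to an amide-type nitrogen in a ring gives a 1.4-fold lower number from compound 3 to compound 4 (0.15 log units; within the scatter), and set beside the earlier pair, the change reads alike on the two cores: the same change on two cores in this assay, a 1.4-fold lower number (0.14 log units; within the scatter) from compound 1 to compound 2 and a 1.4-fold lower number (0.15 log units; within the scatter) from compound 3 to compound 4, 1.0-fold (0.01 log units) apart, within the scatter of two such steps

Within these two pairs, then, the step read on the core of compound 1 also held on the core of compound 3. It does not show that piperidin-1-yl gives stronger inhibition of growth than dimethylamino, as each step stays within the scatter, and two pairs with steps this small cannot show that the change would carry over in the same way to any further core.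

The compounds shown carry only dimethylamino and piperidin-1-yl at this place, so it remains open how a morpholine or a piperazine ring would read there. As far as these compounds go, it also remains open whether a longer chain between the ring nitrogen and the amine would give a step of the same size on both cores.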